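Triazole-linked aryloxyacetic acids: lipophilicity notes, compound 4

A few compounds are considered here, and "the series" means these few. Any claim that something is new, unique, unknown or untested is made for them only; others in the source may bear on it.

Measured so far:
compound 1 `O=C(O)CC1COc2cc(OCc3cn(-c4cccc(Cl)c4)nn3)ccc21`: 1.09
compound 2 `O=C(O)COc1ccc(OCc2cn(-c3ccccc3)nn2)cc1`: "not determined" (no result reported)
compound 3 `O=C(O)COc1ccc(OCc2cn(-c3ccccc3)nn2)cc1F`: -0.23

In a physicochemical assay for lipophilicity, read by HPLC, using the shake flask method, in phosphate buffer, measured as octanol-water partition, with a stated time of 24 h, at pH 7.4, tested at 100 uM (on this read-out higher numbers stand for higher lipophilicity and lower numbers for lower lipophilicity), compound 3 gives -0.23, the lowest of the two numbers available; compound 1 gives 1.09 in this assay, a number higher than that of compound 3 by a margin beyond the scatter. Compound 2 has no result in this assay.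

Compound 4 `Cc1ccc(Cl)cc1-n1cc(COc2ccc(OCC(=O)O)c(F)c2)nn1` has not been measured. It differs from compound 3 in one place: 5-chloro-2-methylphenyl in place of phenyl on an aromatic nitrogen. The entering group carries one chlorine and one more carbon than the phenyl it replaces, and no donor or acceptor count changes. With no measured pair of this kind in the series, the direction and size of the step must be estimated. A rise beyond the scatter is expected, since compound 3 gives -0.23 while compound 1, which also carries a chlorine on its aryl group, gives 1.09. The step expected from this change is a number 1.13 log units higher from compound 3 to compound 4 (beyond the scatter). Compound 4 is estimated at 0.9, within a range of 0.4 to 1.4.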

Compound 4, distribution coefficient: 1.95
Beside the measured number, compound 4's estimate is 1.05 log units below it; measured number outside the range, above it.
By their numbers in this assay, from the lowest: compound 3; then compound 1; then compound 4.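

In this assay, among the compounds shown here, 5-chloro-2-methylphenyl in place of phenyl on an aromatic nitrogen gives a number 2.18 log units higher from compound 3 to compound 4 (beyond the scatter), the first step between compounds that differ in one place. The position on the aromatic nitrogen is thus shown to shift this read-out by a large step, with a change that adds one chlorine and one carbon and leaves the donor and acceptor counts unchanged. No supporting measurement accounts for the size of the step.

The measurements do not separate the chlorine from the methyl in this step. From the compounds shown here alone, whether the same change gives a similar step on the core of compound 1 remains open. Also open, going by these compounds, is how an amine or a carboxylic acid on the aromatic ring at this position would read.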